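A few compounds are considered here, and "the series" means these few. Any claim that something is new, unique, unknown or untested is made for them only; others in the source may bear on it.

Measured in an ADME assay on the whole organism with Oryza sativa as the target, tested at 10 uM; a lower number here means a stronger effect, a higher number a weaker effect of the compound at the concentration tested:
- compound 1 `CCc1ccccc1NC(=O)N[C@H](C)c1ccccc1`: 92%
- compound 2 `CC(=O)c1ccccc1NC(=O)N[C@H](C)c1ccccc1`: 89%

In this assay compound 2 stands at the lower of the two numbers, and compound 1 is nearest with a difference that lies within the scatter. Compound 3 `C[C@@H](NC(=O)Nc1ccccc1Cl)c1ccccc1` is not yet measured; it differs from compound 2 by chloro in place of acetyl on an aromatic carbon. Going by the values given here, the only measured step, a number 3 percentage points lower from compound 1 to compound 2 (within the scatter), was within the scatter, and no measured step involves a chloro group. The step from compound 2 to compound 3 is therefore expected to be a number 1 percentage points higher from compound 2 to compound 3 (within the scatter), nothing beyond the scatter. For compound 3 the estimate in this assay is 90%, with a range from 76% to 100%.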

Compound 3, a percentage reported as activity, at one concentration (the size of the read-out at that concentration, not a potency): 93%
For compound 3 the middle estimate is 3 percentage points below the measured one; measured number inside the range.
By their numbers in this assay, from the lowest: compounds 2, 1 and 3 (each within the scatter of the next).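

Chloro now joins ethyl and acetyl on this aromatic carbon, ortho to a large group, and in this assay neither a number 4 percentage points higher from compound 2 to compound 3 (within the scatter) nor a number 1 percentage points higher from compound 1 to compound 3 (within the scatter) leaves the scatter. A single chlorine atom with no hydrogen-bond acceptor thus reads the same here as acetyl, with its 3 heavy atoms and 1 hydrogen-bond acceptor, so this change in size and acceptor count leaves no measurable mark. Nothing measured here offers an explanation for this. As far as these compounds go, whether an amine, a carboxylic acid or a longer chain on this carbon would move the number beyond the scatter remains open. So does the effect of chloro elsewhere on the ring.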